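Adding fluoro to the phenyl of compound 2

The source may hold more compounds than are shown below. What is called first, only, known or untested is meant among the compounds shown, and "the series" means these compounds.

In a functional assay on DU-145 cells (Homo sapiens) for antiproliferative activity, read by MTT assay, with a stated time of 48 h (a higher number here means a weaker inhibitor, a lower number a stronger inhibitor), compound 1 `C/C(=C\CC/C(C)=C/CC[C@@H]1[C@@]2(C)CCC(=O)C(C)(C)[C@H]2CC[C@@]1(C)O)CC/C=C(\C)C(=O)OCc1cn(-c2ccccc2C(F)(F)F)nn1` is reported only as a limit, > 150000 nM. Among the measured compounds shown here, compound 2 `C/C(=C\CC/C(C)=C/CC[C@@H]1[C@@]2(C)CCC(=O)C(C)(C)[C@H]2CC[C@@]1(C)O)CC/C=C(\C)C(=O)OCc1cn(-c2ccccc2)nn1` gives 95500 nM, the only actual number so far, so it has no measured neighbour to be ranked against.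

The next analogue is compound 3 `C/C(=C\CC/C(C)=C/CC[C@@H]1[C@@]2(C)CCC(=O)C(C)(C)[C@H]2CC[C@@]1(C)O)CC/C=C(\C)C(=O)OCc1cn(-c2cccc(F)c2)nn1`, which keeps the shared core and ester chain. The change is fluoro in place of hydrogen on an aromatic carbon, meta to a large group, turning phenyl into 3-fluorophenyl.

For the measured compounds named here, only one measured step bears on this, also a substitution on the phenyl: an at least 1.5-fold lower number from compound 1 to compound 2 (0.19 log units; that floor lies within the scatter). As far as these compounds go, it swaps trifluoromethyl for hydrogen, and its true size remains open, with the limit of > 150000 nM in this assay, at which 1 of the 2 values shown sits. That step shows no change beyond the scatter, and fluoro is a smaller replacement for hydrogen than trifluoromethyl in heavy-atom count, so no clear shift in either direction is expected in this assay.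

The estimated change, a 1.1-fold lower number from compound 2 to compound 3 (0.03 log units; within the scatter), is expected to stay within the scatter. For compound 3 the expected value is 90000 nM, with an estimated range of 50000 nM to 150000 nM.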

Compound 3, half-maximal inhibitory concentration: > 150000 nM
Compound 3: a limit, no number (the forecaster's own chance of this, stated with the estimate: 20%); middle value at least 1.6-fold (0.22 log units) away from the limit.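

In this assay compound 3 gives > 150000 nM, which is a limit and not a number. Replacing the phenyl of compound 2 with 3-fluorophenyl gives an at least 1.5-fold higher number from compound 2 to compound 3 (0.19 log units; that floor lies within the scatter), so this single fluoro change, meta to a large group, is not shown to move the number beyond the scatter, although its true size may be larger. Both substituted phenyl analogues shown, the 2-(trifluoromethyl)phenyl of compound 1 and the 3-fluorophenyl of compound 3, now end at a limit, leaving compound 2 as the only one with an actual number, and the step from compound 1 to compound 3 cannot be read: the limit of > 150000 nM in this assay, at which 2 of the 3 values shown sit.

As far as these compounds go, it remains open whether any substituent on this phenyl gives a measurable number in this assay alongside that of compound 2, for instance an amine, a hydroxyl or a carboxylic acid on the same aromatic carbon. Also open, from the compounds shown here alone, is how far the 3-fluorophenyl result carries over to analogues with a different ester chain, such as a shorter chain or an amide in place of the ester.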